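Swapping the amide substituent on a chlorinated core

The source may report more compounds than this note shows. Statements on the series, on what has been measured and on what is new or still open speak of the compounds shown alone.

Measured compounds:
- compound 1, `O=C(Nc1cc2cc[nH]c(=O)c2cc1Cl)[C@@H]1CCCN1`: "not determined" (no result reported)
- compound 2, `CC(C)C[C@H](N)C(=O)Nc1cc2cc[nH]c(=O)c2cc1Cl`: "not determined" (no result reported)
- compound 3, `O=C(Nc1cc2cc[nH]c(=O)c2cc1Cl)[C@H]1CCCN1`: 1120 nM

Three compounds share a core, and only one of them has a number in a functional assay (aorta) with Rattus norvegicus as the target; a lower number here means that less compound is needed, a higher number that more compound is needed for the effect. Compound 3 gives 1120 nM in this assay. Compound 1 has no single number there; the same is true of compound 2, so compound 1 cannot be placed against either of its neighbours on the numbers alone. What can be said is the fact that compounds 1 and 3 differ only in the configuration as drawn, so compound 3 is the closest measured relative of compound 1.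

The step from compound 1 to the unmeasured compound 4, `CN1CCC(C(=O)Nc2cc3cc[nH]c(=O)c3cc2Cl)CC1`, is 1-methylpiperidin-4-yl in place of pyrrolidin-2-yl on a carbonyl carbon. For the measured compounds named here, no step between measured compounds is known here, so the size of this one can only be guessed. Going by the values given here, a shift of modest size in either direction seems plausible in this assay, and a result within the usual scatter of the one known value would not be surprising. Because compound 3 gives 1120 nM, compound 4 is expected to give 1500 nM, with a range from 300 nM to 8000 nM.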

Compound 4, half-maximal effective concentration: 250 nM
Beside the measured number, compound 4's estimate is 6.0-fold (0.78 log units) above it, outside the stated range (below it).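

In this assay, the substituent on the carbonyl carbon turns out to matter: 1-methylpiperidin-4-yl in place of pyrrolidin-2-yl brings a 4.5-fold lower number from compound 3 to compound 4 (0.65 log units; beyond the scatter), so less compound is needed for the effect. This first readable step also shows that the position accepts a six-membered ring in place of a five-membered one, even though the new group has no defined stereocentre and no hydrogen-bond donor. The reference for the step is compound 3 rather than compound 1, which has no number, and the link between the two is close: the fact that compounds 1 and 3 differ only in the configuration as drawn.

Steps involving compound 1 or compound 2 cannot be read, so the effect of configuration at pyrrolidin-2-yl remains unknown, as does the effect of the open-chain amine in compound 2. Several features change at once in this swap, so the step cannot be assigned to any one of them; piperidin-4-yl without its methyl, 1-methylpyrrolidin-2-yl or a carboxylic acid at this place would each bear on that question.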